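A methyl added on the carboxy ring of compound 2

The source may hold more compounds than are shown below. What is called first, only, known or untested is meant among the compounds shown, and "the series" means these compounds.

Measured so far:
compound 1 `Cc1c(OCCCCOc2ccc(C(=O)O)cc2)ccc(C(=O)CC(C)C)c1C` gives 19%
compound 2 `Cc1c(OCCCCOc2ccc(C(=O)O)cc2)ccc(C(=O)CC(C)C)c1O` gives 88%

Among the compounds with values here, in an assay on HEK293 cells for positive allosteric modulation of metabotropic glutamate receptor 2 (Rattus norvegicus), read by thallium flux, with a stated time of 2.5 min (on this read-out lower numbers stand for smaller maximal responses and higher numbers for larger maximal responses), compound 1 reaches 19% while compound 2 reaches 88%; compound 2 thus stands highest of the two numbers, its only neighbour being compound 1, a number 69 percentage points higher from compound 1 to compound 2 (beyond the scatter). Compound 3 `Cc1cc(OCCCCOc2ccc(C(=O)CC(C)C)c(O)c2C)ccc1C(=O)O` arises from compound 2 by methyl in place of hydrogen on an aromatic carbon. Within the data shown here, no measured step probes this change: the one known step, a number 69 percentage points higher from compound 1 to compound 2 (beyond the scatter), concerns another group at another place and has no direct bearing. With nothing pointing either way, the step expected in this assay is a number 8 percentage points lower from compound 2 to compound 3 (within the scatter), none beyond the scatter. Compound 3 is therefore estimated at 80%, between 60% and 100%.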

Compound 3, largest response reached (reported as percent of maximum), in percent of the reference or control that the assay uses: 93.3%
Beside the measured number, compound 3's estimate is 13.3 percentage points below it; low and high end bracket the measured number.
By their numbers in this assay, from the lowest: compound 1; then compounds 2 and 3 (each within the scatter of the next).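

Going from 4-carboxyphenyl to 4-carboxy-3-methylphenyl in this assay gives a number 5.3 percentage points higher from compound 2 to compound 3 (within the scatter), so a methyl ortho to a carboxy group leaves the high maximal response of compound 2 intact. The earlier step, a number 69 percentage points higher from compound 1 to compound 2 (beyond the scatter), concerned only hydroxy in place of methyl at another place, and said nothing about this ring. No evidence is available on why the methyl is tolerated here.

From the compounds shown here alone, whether an ethyl, a methoxy or a chlorine at this place would be tolerated as well remains open. So does whether this methyl would have the same outcome alongside the methyl of compound 1.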